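Swapping chloro for methoxy on a well-tolerated compound

The source may hold more compounds than are shown below. What is called first, only, known or untested is meant among the compounds shown, and "the series" means these compounds.

In a functional assay on C8166 cells (Homo sapiens) for cytotoxicity, read by MTT assay, with a stated time of 72 h (a higher number here means that more compound is tolerated, a lower number that less compound is tolerated), compound 1 (`Cc1ccc(S(=O)(=O)N2CC3(C[C@H]2C(=O)N/N=C/c2ccccc2F)SCCS3)cc1`) gives 280000 nM as its half-maximal cytotoxic concentration. Compound 2 (`Cc1ccc(S(=O)(=O)N2CC3(C[C@H]2C(=O)N/N=C/c2ccccc2Cl)SCCS3)cc1`) gives > 404000 nM as a limit of the assay and not a number. Compound 2 therefore stands only at a limit (the limit of > 404000 nM in this assay, at which 1 of the 2 values shown sits) and has no exact place on the scale. Compound 3 (`COc1ccccc1/C=N/NC(=O)[C@@H]1CC2(CN1S(=O)(=O)c1ccc(C)cc1)SCCS2`) carries methoxy in place of chloro on an aromatic carbon, ortho to a large group (methoxy in place of chloro on an aromatic carbon). Going by the values given here, the only measured step that bears on this swap is an at least 1.4-fold higher number from compound 1 to compound 2 (0.15 log units; that floor lies within the scatter) and it involves a different pair of groups on the same kind of carbon, so no change beyond the scatter is expected in this assay. The estimated move is small (an at least 1.1-fold lower number from compound 2 to compound 3 (0.06 log units; that floor lies within the scatter)). The expected value for compound 3 is 350000 nM (estimated range 150000 nM to 800000 nM).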

Compound 3, half-maximal cytotoxic concentration: 388000 nM
Estimate against measurement, compound 3: 1.1-fold (0.04 log units) below; measured number inside the range.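

Compound 3 gives a second exact number at this place on the ring, so two different groups can be compared directly in this assay, and methoxy in place of fluoro gives a 1.4-fold higher number from compound 1 to compound 3 (0.14 log units; within the scatter). Methoxy brings a hydrogen-bond acceptor that chloro does not have, yet the step from chloro to methoxy in this assay reads only as a floor, an at least 1.0-fold lower number from compound 2 to compound 3 (0.01 log units; that floor lies within the scatter). Compound 2 has a limit of the assay and not a number, so the true size of that step cannot be fixed: the limit of > 404000 nM in this assay, at which 1 of the 3 values shown sits.

As far as these compounds go, how far compound 2 lies past its limit remains open. Also open, from the compounds shown here alone, is whether an amine or a carboxylic acid on the same aromatic carbon would leave the number in this assay just as little changed.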